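Methoxy for fluoro on the aryl ring of compound 1

The compounds below may be only part of what the source reports. "The series", "measured", "known", "first", "only" and "open" are said of these compounds alone.

Measured compounds:
compound 1 `CC1=C(/C=C/C(=O)/C=C/c2cccc(F)c2)C(C)(C)CCC1O` 4400 nM
compound 2 `CC1=C(/C=C/C(=O)/C=C/c2cc(F)cc(C(F)(F)F)c2)C(C)(C)CCC1O` 1100 nM
compound 3 `CC1=C(/C=C/C(=O)/C=C/c2cc(C(F)(F)F)ccc2F)C(C)(C)CCC1O` 1700 nM

Three dienones share a core and differ only in the substitution of the phenyl ring. In a functional assay on LNCaP cells (Homo sapiens) for cytotoxicity, read by MTT assay, with a stated time of 72 h (a lower number here means a stronger inhibitor, a higher number a weaker inhibitor), compound 1 gives 4400 nM, the highest number of the three. Among the measured compounds shown here, compound 3 stands nearer to it, with 1700 nM, and compound 2 furthest, with 1100 nM; the step of a 4.0-fold lower number from compound 1 to compound 2 (0.60 log units; beyond the scatter) is the only single change among the measured compounds.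

Compound 4 `COc1cccc(/C=C/C(=O)/C=C/C2=C(C)C(O)CCC2(C)C)c1` is the unmeasured partner of compound 1. The change is methoxy in place of fluoro on an aromatic carbon. For the measured compounds named here, no measured step touches this exchange: the only step known alters a different position by adding a trifluoromethyl group, and it moved the number down by a modest amount. Nothing in the data shows how replacing fluoro with methoxy behaves, so the expectation is a number close to that of compound 1, with a wide range in both directions. For compound 4 the estimate in this assay is 4000 nM (range 1500 nM to 12000 nM), which means an expected step of a 1.1-fold lower number from compound 1 to compound 4 (0.04 log units; within the scatter) within the scatter.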

Compound 4, half-maximal inhibitory concentration: 4900 nM
Compound 4: the middle estimate sits 1.2-fold (0.09 log units) below what was measured, and the stated range covers the measured number.
By their numbers in this assay, from the lowest: compounds 2 and 3 (each within the scatter of the next); then compounds 1 and 4 (each within the scatter of the next).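

In this assay, among the compounds shown here, exchanging 3-fluorophenyl for 3-methoxyphenyl gives a 1.1-fold higher number from compound 1 to compound 4 (0.05 log units; within the scatter), the first reading at this position of a group other than fluoro. For the compounds shown here, on an aromatic carbon meta to a large group, methoxy, with its hydrogen-bond acceptor, and fluoro are therefore not told apart by this assay, whereas the only earlier step, a 4.0-fold lower number from compound 1 to compound 2 (0.60 log units; beyond the scatter), involved adding trifluoromethyl at a different ring carbon. No supporting measurement bears on this result.

The compounds shown leave open whether an amine, a carboxylic acid or a longer chain such as butoxy at this position would also stay within the scatter of compound 1. They also leave open whether methoxy would read the same with trifluoromethyl also on the ring.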